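Carboxy for chloro on the pyridinyl ether of compound 3

A few compounds are considered here, and "the series" means these few. Any claim that something is new, unique, unknown or untested is made for them only; others in the source may bear on it.

Of the compounds shown here, three sharing one core have been tested in an ADME assay on PBMC cells (Homo sapiens) for cytotoxicity; on this read-out lower numbers stand for higher toxicity in this test and higher numbers for lower toxicity in this test. Compound 1 `CC(CCNC(=O)c1c(Cl)cncc1Cl)N1CCC(C(Oc2cccc(C(F)(F)F)c2)c2ccc(C(F)(F)F)cc2)CC1` gives 7000 nM. Compound 2 `CC(CCNC(=O)c1c(Cl)cncc1Cl)N1CCC(C(Oc2ccc(C(F)(F)F)cc2)c2ccc(C(F)(F)F)cc2)CC1` gives 3100 nM, which is a 2.3-fold lower number from compound 1 to compound 2 (0.35 log units; beyond the scatter). Compound 3 `CC(CCNC(=O)c1c(Cl)cncc1Cl)N1CCC(C(Oc2cccc(Cl)n2)c2ccc(C(F)(F)F)cc2)CC1` reaches only the limit of the test, reported as > 32500 nM, so for compound 3 no exact number is known. This is the limit of > 32500 nM in this assay, at which 1 of the 3 values shown sits. Against the two phenyl ethers, the move to the pyridinyl ether is an at least 4.6-fold higher number from compound 1 to compound 3 (0.66 log units; beyond the scatter) and an at least 10-fold higher number from compound 2 to compound 3 (1.02 log units; beyond the scatter), so compound 3 is the least toxic of the three by a clear margin.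

Compound 4 `CC(CCNC(=O)c1c(Cl)cncc1Cl)N1CCC(C(Oc2cccc(C(=O)O)n2)c2ccc(C(F)(F)F)cc2)CC1` has not yet been measured. It differs from compound 3 in one place, (carboxy in place of chloro on an aromatic carbon). Among the measured compounds shown here, none of the measured steps touches a substituent on the pyridinyl ring; they exchange the whole ring, and both of those steps carried the number up to the limit. For the measured compounds named here, there is therefore no direct precedent for this change, and compound 4 is expected to stay where compound 3 already stands, with a step that the limit leaves unreadable from compound 3 to compound 4 and no step beyond the scatter. The estimate for compound 4 is 40000 nM, within a range from 15000 nM to 100000 nM, most likely again reported only as a limit.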

Compound 4, half-maximal cytotoxic concentration: 28700 nM
Beside the measured number, compound 4's estimate is 1.4-fold (0.14 log units) above it, within the range that was stated.
By their numbers in this assay, from the lowest: compound 2; then compound 1; then compound 4. At a limit, above all of these: compound 3.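

In this assay, among the compounds shown here, the carboxy group on the aromatic carbon next to the ring nitrogen gives the first exact number for a pyridinyl ether, so the gain over the phenyl ethers can now be sized, at least for this one group: a 9.3-fold higher number from compound 2 to compound 4 (0.97 log units; beyond the scatter), and a 4.1-fold higher number from compound 1 to compound 4 (0.61 log units; beyond the scatter), while the change from chloro to carboxy comes to an at least 1.1-fold lower number from compound 3 to compound 4 (0.05 log units; that floor lies within the scatter). Carboxy is a very different substituent from chloro by simple count, with more heavy atoms plus a hydrogen-bond donor and acceptor, yet the pyridinyl ether carrying it still stands clearly above both phenyl ethers, so the higher numbers seen with compound 3 are not tied to chloro alone. The change from chloro to carboxy is known only as a floor, because compound 3 sits at a limit of the test rather than at a number: the limit of > 32500 nM in this assay, at which 1 of the 4 values shown sits.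

As far as these compounds go, whether carboxy lowers the number relative to chloro at all therefore stays unknown. Also open, from the compounds shown here alone, is whether an amine or a methyl ester on the same carbon would hold the number as high, and whether carboxy on a phenyl ether would give a similar rise without the ring nitrogen.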